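A methoxy group takes the place of a nitro

The source may report more compounds than this note shows. Statements on the series, on what has been measured and on what is new or still open speak of the compounds shown alone.

Of the compounds shown here, three sharing one core have been measured in a functional assay on RCC4 cells (Homo sapiens) for inhibition, read by XTT assay, with a stated time of 4 days; on this read-out lower numbers stand for stronger inhibition and higher numbers for weaker inhibition. Compound 1 `Brc1cccc(Nc2nc(-c3ccncc3)cs2)c1` gives 40700 nM, compound 2 `Cc1cc(C)cc(Nc2nc(-c3ccncc3)cs2)c1` gives 4570 nM, and compound 3 `O=[N+]([O-])c1ccccc1Nc1nc(-c2ccncc2)cs1` gives 40700 nM. Compound 3 stands level with compound 1 at the digits shown, the two together the highest numbers of the set, while compound 2 lies well below both, beyond the scatter.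

The next compound, compound 4 `COc1ccccc1Nc1nc(-c2ccncc2)cs1`, differs from compound 3 in one place: methoxy in place of nitro on an aromatic carbon. Among the compounds with values here, no measured pair shows this exchange, so no direct guide to its size exists. Only the spread among the three measured compounds, from compound 3 down to compound 2, shows how far this core can move.

For compound 4 the expectation is a modest drop in number, a step in a 2.0-fold lower number from compound 3 to compound 4 (0.31 log units; beyond the scatter) that stays well inside the spread the other three compounds show. The estimate for compound 4 in this assay is 20000 nM, with a range from 5000 nM to 60000 nM.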

Compound 4, half-maximal inhibitory concentration: 33900 nM
For compound 4 the middle estimate is 1.7-fold (0.23 log units) below the measured one, within the range that was stated.
By their numbers in this assay, from the lowest: compound 2; then compounds 4, 1 and 3 (each within the scatter of the next).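

In this assay, methoxy in place of nitro on an aromatic carbon, ortho to a large group, gives a 1.2-fold lower number from compound 3 to compound 4 (0.08 log units; within the scatter), a step within the scatter. So this exchange at this position leaves the number effectively unchanged, even though methoxy brings fewer heavy atoms and fewer hydrogen-bond acceptors than nitro and lacks its double bond. Nothing at hand offers an explanation for this flat result.

The compounds shown carry only nitro and methoxy at this place, so whether an amine or a carboxylic acid there would give a clearly different number remains open. From the compounds shown here alone, it is also open whether methoxy in place of nitro would give an equally small step elsewhere on that six-membered aromatic ring.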